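Methoxy Added to the Phenyl Ring of a Porcupine Inhibitor

The source may report more compounds than this note shows. Statements on the series, on what has been measured and on what is new or still open speak of the compounds shown alone.

Measured so far in an assay on L cells for inhibition of Protein-serine O-palmitoleoyltransferase porcupine (Mus musculus), read by reporter gene assay, with a stated time of 24 h; on this read-out lower numbers stand for an effect already at smaller amounts and higher numbers for an effect only at larger amounts of compound: compound 1 `O=C(CSc1nc2c(c(=O)n1-c1ccccc1)SCC2)Nc1nc2ccc(Cl)cc2s1` gives 40 nM; compound 2 `O=C(CNC(=O)c1nn(-c2ccccc2)c(=O)c2ccccc12)Nc1nc2ccc(Cl)cc2s1` gives 30 nM; compound 3 `COc1ccccc1-n1c(SCC(=O)Nc2nc3ccc(Cl)cc3s2)nc2c(c1=O)SCC2` gives 50 nM.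

All three numbers sit within the scatter of one another. Compound 1 and compound 2 carry different cores; the difference between the two cores is not broken down here. Compound 3 is compound 1 with methoxy in place of hydrogen on an aromatic carbon, and that change gave a 1.3-fold higher number from compound 1 to compound 3 (0.10 log units; within the scatter).

Compound 4 `COc1ccc(-n2nc(C(=O)NCC(=O)Nc3nc4ccc(Cl)cc4s3)c3ccccc3c2=O)cc1` has not yet been measured. It is compound 2 with methoxy in place of hydrogen on an aromatic carbon. The place is not identical: ortho to a large group in compound 3, para to a large group in compound 4, so this is the same kind of change rather than the same change. Because the earlier step was a 1.3-fold higher number from compound 1 to compound 3 (0.10 log units; within the scatter), the expected step is a 1.2-fold higher number from compound 2 to compound 4 (0.07 log units; within the scatter). Compound 4 is estimated at 35 nM, most likely between 15 nM and 90 nM.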

Compound 4, half-maximal effective concentration: 15 nM
Beside the measured number, compound 4's estimate is 2.3-fold (0.37 log units) above it; low and high end bracket the measured number.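

The methoxy change on the second core gave a 2.0-fold lower number from compound 2 to compound 4 (0.30 log units; within the scatter). Set beside the earlier step, the two results do not separate: the same change on two cores in this assay, a 1.3-fold higher number (0.10 log units; within the scatter) from compound 1 to compound 3 and a 2.0-fold lower number (0.30 log units; within the scatter) from compound 2 to compound 4, 2.5-fold (0.40 log units) apart, within the scatter of two such steps. This shows that the change had no effect beyond the scatter on either core, but the methoxy does not stand in the same place in compound 3 and compound 4, and two steps of this size cannot establish a rule for carrying the change to other cores.

Still open, as far as these compounds go, is how methoxy would read at one and the same place on both cores. Also open, from the compounds shown here alone, is whether an amine or a carboxylic acid on that phenyl ring would give similar steps on the two cores.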